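Swapping methoxy for cyano on the anilino ring of compound 1

This account rests on a few compounds, and the source may have more. Where it says the series, first, only, none or still open, it means among the compounds named here.

Going by the values given here, compound 1 `C=CC(=O)Nc1cccc(Oc2nc(Nc3cccc(OC)c3)nc3ccsc23)c1` gives 16400 nM in a functional assay on HeLa cells (Homo sapiens) for inhibition, read by MTT assay, with a stated time of 72 h (a lower number here means a stronger inhibitor, a higher number a weaker inhibitor), the second highest of the three numbers so far. Compound 2 `CC/C=C/C(=O)Nc1cccc(Oc2nc(Nc3cccc(OC)c3)nc3ccsc23)c1` gives 29400 nM, and compound 3 `CCC/C=C/C(=O)Nc1cccc(Oc2nc(Nc3cccc(OC)c3)nc3ccsc23)c1` gives 7730 nM. Every measured step alters only the acyl chain: a 1.8-fold higher number from compound 1 to compound 2 (0.25 log units; within the scatter), a 2.1-fold lower number from compound 1 to compound 3 (0.33 log units; beyond the scatter), and a 3.8-fold lower number from compound 2 to compound 3 (0.58 log units; beyond the scatter). Compound 4 `C=CC(=O)Nc1cccc(Oc2nc(Nc3cccc(C#N)c3)nc3ccsc23)c1` keeps the vinyl amide of compound 1 and differs elsewhere: cyano in place of methoxy on an aromatic carbon. Among the compounds with values here, no measured step touches that ring, so none bears directly on this change, and the chain steps themselves were at most modest. With nothing to set a direction, no step beyond the scatter is expected, and compound 4 is estimated at 16000 nM in this assay, within 5000 nM to 50000 nM, meaning a 1.0-fold lower number from compound 1 to compound 4 (0.01 log units; within the scatter).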

Compound 4, half-maximal inhibitory concentration: 6390 nM
Compound 4: middle estimate off by 2.5-fold (0.40 log units), on the high side, and the stated range covers the measured number.
By their numbers in this assay, from the lowest: compounds 4 and 3 (each within the scatter of the next); then compounds 1 and 2 (each within the scatter of the next).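

Cyano in place of methoxy on the (3-methoxyphenyl)amino group gives a 2.6-fold lower number from compound 1 to compound 4 (0.41 log units; beyond the scatter) in this assay and so shows, modest as the step is, that this assay also responds to a change on this ring, whereas the earlier steps touched only the acyl chain. No measurement at hand explains this change. Still open, from the compounds shown here alone, is whether the same swap holds on the pent-1-en-1-yl amide of compound 3, and how an amine, a carboxylic acid or a longer chain would read at this place on the ring.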